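Thiazolyl for pyridyl on the shared core: cytotoxicity outlook

The source may hold more compounds than are shown below. What is called first, only, known or untested is meant among the compounds shown, and "the series" means these compounds.

Within the data shown here, compound 1 `COc1nc(-c2ccncc2)ccc1[C@@H](c1ccccc1)[C@@](O)(CCN(C)C)c1cccc2ccccc12` is one of two compounds so far measured in a toxicity assay on Vero cells (Chlorocebus sabaeus) for cytotoxicity; a higher number here means that more compound is tolerated, a lower number that less compound is tolerated. In this assay compound 1 gives > 50 ug/mL, which is a limit of the assay and not a number. Compound 2 `COc1ncc(-c2ccccc2)cc1[C@@H](c1ccccc1)[C@@](O)(CCN(C)C)c1cccc(F)c1F` is the other one; in this assay compound 2 gives > 50 ug/mL, again a limit. Among the measured compounds shown here, compound 1 thus stands at the limit of > 50 ug/mL in this assay, at which 2 of the 2 values shown sit, and no measured pair differs in one place, so no step size is on record. Compound 3 `COc1nc(-c2cnsc2)ccc1[C@@H](c1ccccc1)[C@@](O)(CCN(C)C)c1cccc2ccccc12` is not yet measured; it carries 1,2-thiazol-4-yl in place of pyridin-4-yl on an aromatic carbon. For the measured compounds named here, with no measured step to lean on, the expectation in this assay is no step beyond the scatter, the more so because compound 1 sits at the limit of > 50 ug/mL in this assay, at which 2 of the 2 values shown sit. Compound 3 is therefore expected to give 50 ug/mL, with a range of 25 ug/mL to 100 ug/mL, most likely reported once more as a limit. The step of a number no higher from compound 1 to compound 3 (the limit leaves the size open) is estimated to be essentially flat.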

Compound 3, half-maximal cytotoxic concentration: 26.3 ug/mL
Beside the measured number, compound 3's estimate is 1.9-fold (0.28 log units) above it, within the range that was stated.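

In this assay, this place, on an aromatic carbon next to the ring nitrogen, now has its first step: 1,2-thiazol-4-yl in place of pyridin-4-yl comes with an at least 1.9-fold lower number from compound 1 to compound 3 (0.27 log units; that floor lies within the scatter). Compound 3, at 26.3 ug/mL, is the first compound shown with a number rather than a limit in this assay. The step is only a floor and its true size cannot be read, because the value of compound 1 is a limit of the assay and not a number: the limit of > 50 ug/mL in this assay, at which 2 of the 3 values shown sit.

Whether the number of compound 3 goes with the sulfur or with the five-membered ring cannot be told from the compounds shown. As far as these compounds go, how 1,2-oxazol-4-yl, with oxygen in place of the sulfur, would read at this place also stays open.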